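This account rests on a few compounds, and the source may have more. Where it says the series, first, only, none or still open, it means among the compounds named here.

Measured in a functional assay on HCT-116 cells (Homo sapiens) for antiproliferative activity, read by sulforhodamine B assay, with a stated time of 72 h; on this read-out higher numbers stand for weaker inhibition and lower numbers for stronger inhibition:

- Compound 1 `Cn1ncc(Cl)c1-c1cc(C(=O)N[C@@H]2CN[C@H](CCCO)C[C@H]2c2ccc(Cl)c(Cl)c2)oc1Cl`: 510 nM
- Compound 2 `Cn1ncc(Cl)c1-c1cc(C(=O)N[C@@H]2CN[C@H](CCN3CCCCC3)C[C@H]2c2ccc(Cl)c(Cl)c2)oc1Cl`: 1020 nM

Compound 2 gives 1020 nM, which lies within the scatter of compound 1 at 510 nM, so the two cannot be ranked. Compound 3 `Cn1ncc(Cl)c1-c1cc(C(=O)N[C@@H]2CN[C@H](CC(N)=O)C[C@H]2c2ccc(Cl)c(Cl)c2)oc1Cl` has not yet been measured. It differs from compound 2 as follows: carbamoyl in place of (piperidin-1-yl)methyl on a saturated chain carbon bound to a saturated ring carbon. In words, this is carbamoyl in place of (piperidin-1-yl)methyl on a saturated chain carbon bound to a saturated ring carbon.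

Among the measured compounds shown here, only one measured step bears on this part of the structure: a 2.0-fold higher number from compound 1 to compound 2 (0.30 log units; within the scatter). That step put piperidin-1-yl in place of hydroxymethyl on a saturated chain carbon, two bonds along the chain from a saturated ring carbon, and it stayed within the scatter. For the measured compounds named here, no measured compound carries a carbamoyl group, so this evidence is indirect, and no step beyond the scatter is expected in this assay. The expected size is a 1.4-fold lower number from compound 2 to compound 3 (0.13 log units; within the scatter). For compound 3 the estimated value is 750 nM, with an expected range from 300 nM to 1900 nM.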

Compound 3, half-maximal inhibitory concentration: 650 nM
Compound 3: middle estimate off by 1.2-fold (0.06 log units), on the high side; measured number inside the range.
By their numbers in this assay, from the lowest: compounds 1, 3 and 2 (each within the scatter of the next).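

In this assay, carbamoyl in place of (piperidin-1-yl)methyl gives a 1.6-fold lower number from compound 2 to compound 3 (0.20 log units; within the scatter), and carbamoyl in place of 2-hydroxyethyl gives a 1.3-fold higher number from compound 1 to compound 3 (0.11 log units; within the scatter), so the three groups at this place cannot be ranked. Among the compounds shown here, the earlier pair had compared only two longer groups, whereas this result shows that a group of 3 heavy atoms with no ring, replacing one of 7 heavy atoms with a six-membered non-aromatic ring, also leaves the number within the scatter in this assay. Nothing available here accounts for this lack of separation.

Going by these compounds, it remains open whether any group on this saturated chain carbon bound to a saturated ring carbon can move the number beyond the scatter, for example a primary amine, a carboxylic acid or a longer chain ending in carbamoyl. On these data alone, all three compounds share the same core and the same dichlorophenyl group, so it is also open whether the same replacements would stay within the scatter on a different core.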